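A few compounds are considered here, and "the series" means these few. Any claim that something is new, unique, unknown or untested is made for them only; others in the source may bear on it.

The series shares one core, seen in compound 1 `Oc1ccc(CNc2cc(C(F)(F)F)cc3[nH]ncc23)cc1`, which in an assay for inhibition of Indoleamine 2,3-dioxygenase 1 (Homo sapiens), with stated times of 10 min and 60 min, tested at 100 uM (a lower number here means a weaker effect, a higher number a stronger effect of the compound at the concentration tested), gives 81%. Compound 2 `O=[N+]([O-])c1ccc(Cl)cc1CNc1cc(C(F)(F)F)cc2[nH]ncc12` gives 65% in this assay. Compound 3 `O=C(O)CNc1cccc(CNc2cc(C(F)(F)F)cc3[nH]ncc23)c1` stands lowest of the three in this assay with 8%, a number that lies beyond the scatter from both of the others, nearer to compound 2 than to compound 1.

Compound 4 `CNC(=O)c1cccc(CNc2cc(C(F)(F)F)cc3[nH]ncc23)c1` has not yet been measured. It differs from compound 3 in one place: methylcarbamoyl in place of (carboxymethyl)amino on an aromatic carbon. For the measured compounds named here, no pair of measured compounds traces this change, so the direction can be judged only from where compound 3 sits, at the bottom of a spread in which compound 1 and compound 2 both reach high numbers. On that footing the step to compound 4 is expected to run upward and to exceed the scatter, estimated at a number 37 percentage points higher from compound 3 to compound 4 (beyond the scatter). On these data alone, that expectation rests on the low value of compound 3, 8%, set against the higher readings of the other two, and carries real uncertainty, since the change itself is untested. Compound 4 is therefore estimated at 45% in this assay, with a range from 15% to 75%.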

Compound 4, a percentage reported as inhibition, at one concentration (the size of the read-out at that concentration, not a potency): 46%
Compound 4: middle estimate off by 1 percentage points, on the low side; the measured number falls inside the stated range.
By their numbers in this assay, from the lowest: compound 3; then compound 4; then compound 2; then compound 1.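

In this assay, for the compounds shown here, placing methylcarbamoyl in place of (carboxymethyl)amino on this aromatic carbon, meta to a large group, gives a number 38 percentage points higher from compound 3 to compound 4 (beyond the scatter) in the first pair of the series that differs in one place. The read-out therefore responds strongly to the group at this position, and the low number of compound 3 cannot be a property of the shared core alone. The entering group has fewer heavy atoms, hydrogen-bond donors and hydrogen-bond acceptors than the group it replaces, but nothing available shows which of these differences, if any, accounts for the step.

The compounds shown do not separate the loss of the carboxylic acid from the gain of the amide, a question that a carboxylic acid attached directly to the ring, a simple amine or a primary amide on the same carbon would help to settle. Also open, on these data alone, is how far the reading depends on the amide's substitution, which a longer chain on the amide nitrogen would begin to test.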